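From ethoxy to butoxy: working notes on the series

The source may report more compounds than this note shows. Statements on the series, on what has been measured and on what is new or still open speak of the compounds shown alone.

In a functional assay on HL-60 cells (Homo sapiens) for cytotoxicity, read by WST assay, with a stated time of 48 h (a lower number here means that less compound is needed, a higher number that more compound is needed for the effect), compound 1 `Clc1ccc(C[C@H]2COC[C@@H]2Cc2ccccc2)cc1Cl` gives 19000 nM and compound 2 `Oc1ccccc1C[C@H]1COC[C@@H]1Cc1ccc(Cl)c(Cl)c1` gives 34000 nM in the same read-out. Compound 3 `CCOc1ccccc1C[C@H]1COC[C@@H]1Cc1ccc(Cl)c(Cl)c1` gives 29000 nM and so stands within the scatter of both.

Compound 4 `CCCCOc1ccccc1C[C@H]1COC[C@@H]1Cc1ccc(Cl)c(Cl)c1` follows from compound 3 through ethyl in place of hydrogen on a saturated chain carbon, two bonds along the chain from an oxygen on an aromatic ring and reads as ethoxy to butoxy.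

Within the data shown here, three measured steps bear on this change. Hydroxy in place of hydrogen on an aromatic carbon gave a 1.8-fold higher number from compound 1 to compound 2 (0.25 log units; within the scatter) and ethoxy in place of that hydrogen gave a 1.5-fold higher number from compound 1 to compound 3 (0.18 log units; within the scatter) while ethyl in place of hydrogen on the oxygen gave a 1.2-fold lower number from compound 2 to compound 3 (0.07 log units; within the scatter) and none of them leaves the scatter. Among the measured compounds shown here, no measured step extends a saturated chain, so this evidence is indirect. In this assay, going by these compounds, no step beyond the scatter is therefore expected, and the direction stays open. The step expected is a 1.1-fold lower number from compound 3 to compound 4 (0.03 log units; within the scatter) as a working estimate. For compound 4 the estimated value is 27000 nM with an expected range from 13000 nM to 55000 nM around it.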

Compound 4, half-maximal effective concentration: 20000 nM
Compound 4: middle estimate off by 1.4-fold (0.13 log units), on the high side, and the stated range covers the measured number.
By their numbers in this assay, from the lowest: compounds 1, 4, 3 and 2 (each within the scatter of the next).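

Lengthening ethoxy to butoxy at this position gives a 1.5-fold lower number from compound 3 to compound 4 (0.16 log units; within the scatter) in this assay and thus adds a direct reading on a longer saturated chain on the oxygen, which stays within the scatter. Butyl in place of hydrogen on the oxygen gives a 1.7-fold lower number from compound 2 to compound 4 (0.23 log units; within the scatter) and butoxy in place of hydrogen on the aromatic carbon gives a 1.1-fold higher number from compound 1 to compound 4 (0.02 log units; within the scatter) in the same read-out, so hydrogen, hydroxy, ethoxy and butoxy at this place are not told apart here. No measured evidence bears on the reason for this flat reading.

Going by these compounds, whether a longer chain such as hexyloxy would leave the scatter remains open. So does the reading for a chain that ends in an amine or a carboxylic acid.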